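Bromophenyl in Place of a Silicon Group: Compound 4

The compounds below may be only part of what the source reports. "The series", "measured", "known", "first", "only" and "open" are said of these compounds alone.

Measured so far in a functional assay on SW-620 cells (Homo sapiens) for antiproliferative activity, read by MTT assay, with a stated time of 72 h; on this read-out higher numbers stand for weaker inhibition and lower numbers for stronger inhibition:
compound 1, `C[Si](C)(C)c1cn(C[C@H](O)[C@H]2OC(=O)C(OCc3ccccc3)=C2OCc2ccccc2)nn1`, 56000 nM
compound 2, `O=C1O/C(=C\Cn2cc(-c3ccc(Br)cc3)nn2)C(OCc2ccccc2)=C1OCc1ccccc1`, a limit of > 100000 nM
compound 3, `O=C1O/C(=C\Cn2cc(-c3cc(C(F)(F)F)cc(C(F)(F)F)c3)nn2)C(OCc2ccccc2)=C1OCc1ccccc1`, a limit of > 100000 nM

For the measured compounds named here, compound 1 holds the only number among the three results; its value in this assay is weak inhibition. The other two results are limits, not numbers, as the limit of > 100000 nM in this assay, at which 2 of the 3 values shown sit, records. Going by the values given here, no pair among the measured compounds differs in a single place, so no measured step can be drawn from them.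

Compound 4, `O=C1O[C@H]([C@@H](O)Cn2cc(-c3ccc(Br)cc3)nn2)C(OCc2ccccc2)=C1OCc1ccccc1`, keeps the core of compound 1 and changes one group: a group of 7 heavy atoms (6 carbon, 1 bromine; one six-membered aromatic ring of carbon only) in place of a group of 4 heavy atoms (3 carbon, 1 silicon; no ring), on an aromatic carbon. The same 4-bromophenyl group is carried by compound 2, on a different core, and the result for compound 2 is a limit. Compound 1 is itself far from potent, so the step from compound 1 to compound 4 is expected to be small, toward weaker inhibition or no change beyond the scatter, with some chance that only a limit is returned. The step from compound 1 to compound 4 is estimated as a 1.4-fold higher number from compound 1 to compound 4 (0.15 log units; within the scatter). Compound 4 is expected to give about 80000 nM in this assay, within a range from 30000 nM to 200000 nM.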

Compound 4, half-maximal inhibitory concentration: 3760 nM
Estimate against measurement, compound 4: 21-fold (1.33 log units) above; measured number below the stated range.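

In this assay, the group on the aromatic carbon of the five-membered aromatic ring with 3 nitrogen clearly matters: with the rest of the molecule unchanged, 4-bromophenyl in place of the group of 3 carbon and 1 silicon gives a 15-fold lower number from compound 1 to compound 4 (1.17 log units; beyond the scatter). For the compounds shown here, the earlier compounds offered no measured step, so this is the first direct reading of a change at this position, and it shows that this place accepts a larger, ring-bearing group and that the exchange goes with stronger inhibition. The results for compound 2 and compound 3, which also carry aryl groups on this ring, are limits and yield no readable step to compound 4: the limit of > 100000 nM in this assay, at which 2 of the 4 values shown sit.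

On these data alone, a single pair cannot separate the contribution of the bromine from that of the aromatic ring itself, so it remains open how an unsubstituted phenyl ring, a chloro or methoxy group in the bromine's place, or a longer alkyl chain would read at this carbon. The compounds shown also leave open whether the same exchange would give a step of similar size on another core.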